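Para-substituent swap on the benzylamine of compound 1

The compounds below may be only part of what the source reports. "The series", "measured", "known", "first", "only" and "open" are said of these compounds alone.

Measured compounds:
compound 1 `CC(C)(C)c1ccc(CNCCCNS(=O)(=O)c2cc(C(F)(F)F)cc(C(F)(F)F)c2)cc1` — 2300 nM
compound 2 `O=S(=O)(NCCNCc1ccc(-c2ccccc2)cc1)c1cc(C(F)(F)F)cc(C(F)(F)F)c1` — 2700 nM
compound 3 `O=[N+]([O-])c1ccc(S(=O)(=O)NCCCCCCNCc2ccc(Br)cc2)cc1` — 9800 nM

In a functional assay on MIA PaCa-2 cells (Homo sapiens) for inhibition, read by MTT assay, with a stated time of 72 h (on this read-out lower numbers stand for stronger inhibition of growth and higher numbers for weaker inhibition of growth), compound 1 gives the lowest of the three numbers. Compound 2 sits within the scatter of compound 1, so no order between them can be read; compound 3 gives a number beyond the scatter, higher than compound 1. Compound 4 `O=S(=O)(NCCCNCc1ccc(C(F)(F)F)cc1)c1cc(C(F)(F)F)cc(C(F)(F)F)c1` has not been measured. It differs from compound 1 by trifluoromethyl in place of tert-butyl on an aromatic carbon. Among the measured compounds shown here, no measured pair shows this change, so its effect can only be guessed. The author expects no step beyond the scatter from compound 1 to compound 4, with a 1.3-fold higher number from compound 1 to compound 4 (0.12 log units; within the scatter) as the estimated change. Compound 4 is therefore estimated at 3000 nM, with a range from 1200 nM to 7500 nM.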

Compound 4, concentration for 50% growth inhibition: 2500 nM
Compound 4: the middle estimate sits 1.2-fold (0.08 log units) above what was measured, within the range that was stated.
By their numbers in this assay, from the lowest: compounds 1, 4 and 2 (each within the scatter of the next); then compound 3.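

In this assay, among the compounds shown here, the change from 4-(tert-butyl)benzyl to 4-(trifluoromethyl)benzyl gives the first single-place comparison in this set, with a 1.1-fold higher number from compound 1 to compound 4 (0.04 log units; within the scatter) as its step. At this aromatic carbon, tert-butyl and trifluoromethyl therefore cannot be told apart on this read-out. Nothing measured here bears on the reason for this result. On these data alone, whether an amine or a carboxylic acid at this carbon would also give a number within the scatter stays open. So does whether the same swap would read alike on a compound with a longer chain.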